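A few compounds are considered here, and "the series" means these few. Any claim that something is new, unique, unknown or untested is made for them only; others in the source may bear on it.

Compound 1 `O=C1[C@@H](NS(=O)(=O)c2ccc(-c3ccccn3)s2)CCN1Cc1cc2[nH]cccc-2n1` belongs to a small set of sulfonamides examined in an assay on isolated protein for inhibition of coagulation factor X (Oryctolagus cuniculus), tested at 1 uM; on this read-out higher numbers stand for more inhibition at the one concentration tested (going by the name of the read-out) and lower numbers for less inhibition. In this assay compound 1 gives 8%, the lowest of the two numbers available. For the measured compounds named here, the only other measured member, compound 2 `Cc1c(S(=O)(=O)N[C@H]2CCN(Cc3cc4cc[nH]cc-4n3)C2=O)sc2ccc(Cl)cc12`, is built on a different core and gives 52% in this assay, a number that lies beyond the scatter above compound 1. Since the two compounds differ in more than one place, the gap between them cannot be tied to any single change.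

Compound 3 `O=C1[C@@H](NS(=O)(=O)c2ccc(-c3ccon3)s2)CCN1Cc1cc2[nH]cccc-2n1` is a closer relative of compound 1. It differs in one place (1,2-oxazol-3-yl in place of pyridin-2-yl on an aromatic carbon), the entering 1,2-oxazol-3-yl sitting on the five-membered aromatic ring with one sulfur, next to the ring sulfur. Going by the values given here, no measured pair isolates this kind of exchange, so the account leans only on compound 1. The step of a number 2 percentage points higher from compound 1 to compound 3 (within the scatter) is expected to be small and not beyond the scatter. Compound 3 is therefore estimated to give about 10% in this assay, within a range of 0% to 30%.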

Compound 3, a percentage reported as inhibition, at one concentration (the size of the read-out at that concentration, not a potency): 31%
For compound 3 the middle estimate is 21 percentage points below the measured one, outside the stated range (above it).
By their numbers in this assay, from the lowest: compound 1; then compound 3; then compound 2.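

In this assay, for the compounds shown here, the exchange of pyridin-2-yl for 1,2-oxazol-3-yl on an aromatic carbon, next to the ring sulfur, gives a number 23 percentage points higher from compound 1 to compound 3 (beyond the scatter) and is the first single-place step available in this set. It shows that the group at this position can by itself shift the inhibition measured at the one concentration tested, with the rest of the structure unchanged. The measurements do not show which feature of the exchange accounts for the step.

From the compounds shown here alone, it remains open whether a 1,3-thiazol-2-yl ring, a carboxylic acid or a simple amine at this position would give a higher or lower number. Also open, going by these compounds, is whether the same exchange would give a step of similar size on a different core.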